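From Chloro to Hydroxy: Expecting a Modest Gain

The compounds below may be only part of what the source reports. "The series", "measured", "known", "first", "only" and "open" are said of these compounds alone.

Measured compounds in an assay for inhibition of alcohol dehydrogenase (Equus caballus), read by spectrophotometry, in the presence of a further agent that is not named here; a lower number here means tighter binding, a higher number weaker binding:
compound 1 `ClCCc1cc[nH]n1`, 200000 nM
compound 2 `OCc1cn[nH]c1`, 3600 nM
compound 3 `OCCCc1cc[nH]n1`, 60000 nM

Among these three, compound 1 gives the highest number in this assay; compound 3 lies closest to it, compound 2 furthest. Compound 4 `OCCc1cc[nH]n1` carries hydroxy in place of chloro on a saturated chain carbon, two bonds along the chain from an aromatic carbon. Among the measured compounds shown here, one measured step bears directly on this change: a 3.3-fold lower number from compound 1 to compound 3 (0.52 log units; beyond the scatter), in which the same chloro gave way to hydroxymethyl. For the measured compounds named here, compound 2, which also bears a hydroxy group, sits far below compound 1, but no single-point step connects the two. A downward step of similar, modest size is therefore expected for compound 4, estimated at 50000 nM with a range from 15000 nM to 150000 nM, so that a 4.0-fold lower number from compound 1 to compound 4 (0.60 log units; beyond the scatter) is anticipated.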

Compound 4, dissociation constant: 170000 nM
Compound 4: the middle estimate sits 3.4-fold (0.53 log units) below what was measured; measured number above the stated range.
By their numbers in this assay, from the lowest: compound 2; then compound 3; then compounds 4 and 1 (each within the scatter of the next).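

In this assay, hydroxy in place of chloro on this saturated chain carbon gives a 1.2-fold lower number from compound 1 to compound 4 (0.07 log units; within the scatter), so this exchange alone leaves no change that can be told from the scatter. The hydroxy-bearing chains do separate, with a 2.8-fold higher number from compound 3 to compound 4 (0.45 log units; beyond the scatter), so the step seen with hydroxymethyl in place of chloro does not carry over to hydroxy. Nothing available here accounts for this difference. From the compounds shown here alone, what remains open is how an amine or a carboxylic acid would read at this position, and whether a longer chain ending in hydroxy would give a lower number than compound 3.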